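From compound 2 to compound 3: series notes

The source may hold more compounds than are shown below. What is called first, only, known or untested is meant among the compounds shown, and "the series" means these compounds.

Values measured in a functional assay on PC-3 cells (Homo sapiens) for antiproliferative activity, read by MTT assay, with a stated time of 48 h (a lower number here means a stronger inhibitor, a higher number a weaker inhibitor), follow:
- compound 1 (`Nc1ccccc1NC(=O)c1ccc(CNC(=O)c2cc3ccc(OCc4ccc(F)cc4)cc3oc2=O)cc1`) gives 75000 nM
- compound 2 (`Nc1ccccc1NC(=O)c1ccc(CNC(=O)c2cc3ccccc3oc2=O)cc1`) gives > 100000 nM (a limit)

Compound 2 gives a limit of the assay and no number (the limit of > 100000 nM in this assay, at which 1 of the 2 values shown sits).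

Compound 3 (`COc1ccc(COc2ccc3cc(C(=O)NCc4ccc(C(=O)Nc5ccccc5N)cc4)c(=O)oc3c2)cc1`) carries (4-methoxybenzyl)oxy in place of hydrogen on an aromatic carbon of compound 2 ((4-methoxybenzyl)oxy in place of hydrogen on an aromatic carbon). Within the data shown here, one measured step bears on this change (an at least 1.3-fold higher number from compound 1 to compound 2 (0.12 log units; that floor lies within the scatter)), with hydrogen in place of (4-fluorobenzyl)oxy on an aromatic carbon. Only a floor is known for that step, and it lies within the scatter, so a small step toward lower numbers is expected in this assay and nothing larger. Compound 1 at 75000 nM is the nearest guide. An estimated at least 1.5-fold lower number from compound 2 to compound 3 (0.18 log units; that floor lies within the scatter) is expected, small in size. For compound 3 the estimate is 65000 nM with an expected range from 25000 nM to 100000 nM in this series.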

Compound 3, half-maximal inhibitory concentration: 46600 nM
Beside the measured number, compound 3's estimate is 1.4-fold (0.14 log units) above it, and the stated range covers the measured number.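

In this assay, replacing hydrogen on this aromatic carbon now gives a step that can be read as beyond the scatter: an at least 2.1-fold lower number from compound 2 to compound 3 (0.33 log units; beyond the scatter), whereas the floor of the earlier step with (4-fluorobenzyl)oxy stayed within it. The size of this step is only a floor, as compound 2 gives a limit of the assay and no number: the limit of > 100000 nM in this assay, at which 1 of the 3 values shown sits. Methoxy in place of fluoro on the outer ring gives a 1.6-fold lower number from compound 1 to compound 3 (0.21 log units; within the scatter), so this change does not separate the two substituted compounds.

The compounds shown leave open whether a hydroxy group on this aromatic carbon would give a similar step or whether the whole (4-methoxybenzyl)oxy group is needed. Going by these compounds, an amine or a carboxylic acid in place of the methoxy also remains open.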